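A few compounds are considered here, and "the series" means these few. Any claim that something is new, unique, unknown or untested is made for them only; others in the source may bear on it.

Compound 1, `CC1=C(C(=O)OC(C)(C)C)C(c2ccoc2)NC(=O)N1`, gives 2%.
Compound 2, `CC1=C(C(=O)OC(C)(C)C)C(c2cccs2)NC(=O)N1`, gives 7%.
Compound 3, `CC1=C(C(=O)OC(C)(C)C)C(c2cccs2)NC(=O)N1C`, gives 22%.

These three values come from an assay on membranes from HeLa cells for displacement of a labelled ligand from adenosine receptor A3 (Homo sapiens), read by scintillation counting, with a stated time of 180 min, tested at 1 uM; on this read-out lower numbers stand for less inhibition and higher numbers for more inhibition at the one concentration tested (going by the name of the read-out). Compound 2 stands second highest of the three numbers; its nearest neighbour is compound 1, and the difference a number 5 percentage points higher from compound 1 to compound 2 (within the scatter) lies within the usual scatter, so the two cannot be put in order. Compound 3 lies further away, with a number 15 percentage points higher from compound 2 to compound 3 (beyond the scatter), a modest rise that is real.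

Compound 4, `CCC(CC)OC(=O)C1=C(C)NC(=O)NC1c1cccs1`, has not been measured. It differs from compound 2 in one place: pentan-3-yl in place of tert-butyl on an oxygen next to a carbonyl group. Both measured steps leave the ester untouched: one swaps the aromatic ring on the saturated ring carbon, the other puts a methyl on the amide-type nitrogen in the ring. For the measured compounds named here, neither of them therefore says anything about the ester, and nothing among the measured compounds shows how an exchange of one branched alkyl for another on that oxygen behaves. Going by the values given here, with no step that bears on it, the expectation is that the exchange a number 1 percentage points higher from compound 2 to compound 4 (within the scatter) stays within the scatter, in no particular direction. Compound 4 is therefore estimated at 8%, with a range from -5% to 25%.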

Compound 4, a percentage reported as inhibition, at one concentration (the size of the read-out at that concentration, not a potency): 1%
For compound 4 the middle estimate is 7 percentage points above the measured one; measured number inside the range.
By their numbers in this assay, from the lowest: compounds 4, 1 and 2 (each within the scatter of the next); then compound 3.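

In this assay, for the compounds shown here, the exchange of pentan-3-yl for tert-butyl on an oxygen next to a carbonyl group gives a number 6 percentage points lower from compound 2 to compound 4 (within the scatter) and is the only measured change at this position. Going from a tert-butyl group of 4 carbon atoms to a pentan-3-yl group of 5 carbon atoms therefore produces no difference that can be read on this measurement, so this one swap of a branched alkyl group for another leaves the two compounds indistinguishable. The information shown offers no explanation for this result.

From the compounds shown here alone, it remains open whether the same position would respond differently to a group of another kind, such as a longer straight chain, a benzyl group, or a free carboxylic acid in place of the ester. Also open, going by these compounds, is whether the methyl on the amide-type nitrogen, which brought a number 15 percentage points higher from compound 2 to compound 3 (beyond the scatter) when the ester carried tert-butyl, would have a similar effect in a compound carrying pentan-3-yl on that oxygen.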